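A few compounds are considered here, and "the series" means these few. Any claim that something is new, unique, unknown or untested is made for them only; others in the source may bear on it.

For the measured compounds named here, in an ADME assay on microsomes from liver (Mus musculus) for metabolic stability, read by LC-MS, using NADPH, with a stated time of 60 min, tested at 0.1 uM (on this read-out lower numbers stand for a less stable compound and higher numbers for a more stable compound), compound 3 `Fc1ccc(Nc2cc3[nH]c(Nc4ccc(N5CCNCC5)cn4)nc3cn2)cc1F` gives 75%, the highest of the three numbers so far, ahead of compound 1 `Fc1ccc(Nc2cc3[nH]c(Nc4ccc(N5CCNCC5)cn4)nc3cn2)cc1C(F)(F)F` at 55% and compound 2 `Fc1ccc(Nc2cc3[nH]c(Nc4ccc(N5CCN(CC6CC6)CC5)cn4)nc3cn2)cc1C(F)(F)F` at 41%. Compound 4 `Fc1ccc(Nc2cc3[nH]c(Nc4ccc(N5CCN(CC6CC6)CC5)cn4)nc3cn2)cc1F` carries one change from compound 3: cyclopropylmethyl in place of hydrogen on an amine nitrogen in a ring. In words, cyclopropylmethyl takes the place of hydrogen on an amine nitrogen in a ring, turning piperazin-1-yl into 4-(cyclopropylmethyl)piperazin-1-yl. The same replacement has one measured precedent, a number 14 percentage points lower from compound 1 to compound 2 (beyond the scatter). The swap of trifluoromethyl for fluoro gave a number 20 percentage points higher from compound 1 to compound 3 (beyond the scatter), so the starting number here is higher. Going by the values given here, with only that one precedent as a guide, a fall of similar size is expected in this assay, a number 15 percentage points lower from compound 3 to compound 4 (beyond the scatter). Compound 4 is estimated at 60%, within an expected range of 46% to 74%.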

Compound 4, percent of the compound remaining: 14%
Beside the measured number, compound 4's estimate is 46 percentage points above it; measured number below the stated range.
By their numbers in this assay, from the lowest: compound 4; then compound 2; then compound 1; then compound 3.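

With fluoro on the aromatic carbon, cyclopropylmethyl on the ring nitrogen gives a number 61 percentage points lower from compound 3 to compound 4 (beyond the scatter) in this assay, so the size of this change depends on the group elsewhere in the molecule: the same change on two cores in this assay, a number 14 percentage points lower (beyond the scatter) from compound 1 to compound 2 and a number 61 percentage points lower (beyond the scatter) from compound 3 to compound 4, 47 percentage points apart, beyond the scatter of two such steps. The fluoro swap, a gain with the free ring nitrogen, turns into a loss with cyclopropylmethyl present, giving a number 27 percentage points lower from compound 2 to compound 4 (beyond the scatter): the same change on two cores in this assay, a number 20 percentage points higher (beyond the scatter) from compound 1 to compound 3 and a number 27 percentage points lower (beyond the scatter) from compound 2 to compound 4, 47 percentage points apart, beyond the scatter of two such steps.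

The compounds shown leave open whether a methyl or a 2-hydroxyethyl on that ring nitrogen would follow cyclopropylmethyl. Where a chloro or a nitrile on the aromatic carbon would fall also stays open.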